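Double-Bond Geometry and Cytotoxicity in Two Chain Isomers

The source may hold more compounds than are shown below. What is called first, only, known or untested is meant among the compounds shown, and "the series" means these compounds.

Measured so far:
compound 1, `CC(C)=CC(=O)/C=C(/C)CCC/C(C)=C/CC[C@@H](C)O`: 5.1 ug/mL
compound 2, `CC(C)=CC(=O)C/C(C)=C/CC/C(C)=C/CC[C@@H](C)O`: 2.2 ug/mL

Both compounds were tested in a functional assay on P388 cells (Mus musculus) for cytotoxicity, read by MTT assay, with a stated time of 4 days; on this read-out higher numbers stand for weaker inhibition and lower numbers for stronger inhibition. Compound 1 gives 5.1 ug/mL, the highest of the two numbers shown. Compound 2 gives 2.2 ug/mL, a lower number, and the gap between the two lies beyond the usual scatter of repeated measurements, so compound 2 counts as the more potent of the pair.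

Compound 3, `CC(C)=CC(=O)/C=C(\C)CCC/C(C)=C/CC[C@@H](C)O`, has not yet been measured. It keeps every atom and bond of compound 1 and differs from it only in the drawn configuration: the two compounds have the same atoms and bonds and differ only in configuration as drawn: 1 of 3 stereo elements differ; a double bond is drawn Z in compound 1 and E in compound 3. Within the data shown here, no measured pair in this set shows such a change in geometry alone, so there is no directly comparable step to lean on.

In this assay a change of configuration at one double bond is expected to move the number only modestly, with no clear direction, and most plausibly to stay within or close to the scatter; the expected step is a 1.3-fold lower number from compound 1 to compound 3 (0.11 log units; within the scatter). Compound 3 is therefore estimated at 4 ug/mL, with a range from 1.5 ug/mL to 12 ug/mL.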

Compound 3, half-maximal inhibitory concentration: 50 ug/mL
For compound 3 the middle estimate is 13-fold (1.10 log units) below the measured one; measured number outside the range, above it.
By their numbers in this assay, from the lowest: compound 2; then compound 1; then compound 3.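

In this assay, reversing the drawn geometry of a single double bond, from Z to E, gives a 9.8-fold higher number from compound 1 to compound 3 (0.99 log units; beyond the scatter), so this position is sensitive to configuration alone, and the Z form as drawn carries the lower number. Among these compounds, no earlier pair in the set isolated geometry, and this step now shows that a change in one of the three stereo elements, with no atom or bond gained or lost, can be enough to shift cytotoxicity well past the usual scatter of the read-out. The step can be ascribed to this double bond's configuration and to nothing else in the structure, because the comparison is a clean one: the fact that compounds 1 and 3 differ only in the configuration as drawn

The compounds shown leave open whether the other two stereo elements respond as strongly to a change in configuration, or whether this sensitivity belongs to this one double bond alone. They also leave open what an amine or a carboxylic acid in place of the hydroxyl, or a longer chain, would do to the number in this assay, and whether either geometry would keep its standing with such a group present.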